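Shortening the acyl chain of a coumarin ester

This account rests on a few compounds, and the source may have more. Where it says the series, first, only, none or still open, it means among the compounds named here.

Compound 2 `CCCCCCC(=O)OCc1ccc2oc(=O)c(C(=O)Oc3cccc(Br)c3)cc2c1` carries a hexylcarbonyl ester on the shared core. In a functional assay on HT-1080 cells (Homo sapiens), read by transwell migration, with a stated time of 24 h, tested at 1 uM (on this read-out lower numbers stand for a stronger effect and higher numbers for a weaker effect at the one concentration tested), compound 2 gives 55.6%. Compound 1 `CCCCC(=O)OCc1ccc2oc(=O)c(C(=O)Oc3cccc(Br)c3)cc2c1`, with a shorter chain on the same ester, gives 63.3% in this assay, and the step of a number 7.7 percentage points lower from compound 1 to compound 2 (within the scatter) lies within the scatter, so the two numbers cannot be told apart. Compound 3 `CC(C)(C)C(=O)OCc1ccc2oc(=O)c(C(=O)Oc3cccc(Br)c3)cc2c1` differs from compound 2 by tert-butyl in place of hexyl on a carbonyl carbon. Within the data shown here, only one measured step bears on this change, the chain-length step a number 7.7 percentage points lower from compound 1 to compound 2 (within the scatter), and it produced no effect beyond the scatter. Replacing the hexyl with a tert-butyl at the same place is therefore expected to leave this assay essentially unchanged, with the step of a number 4.4 percentage points higher from compound 2 to compound 3 (within the scatter) estimated to stay within the scatter. Compound 3 is expected to give about 60%, between 45% and 75%.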

Compound 3, a percentage reported as activity, at one concentration (the size of the read-out at that concentration, not a potency): 48.2%
Beside the measured number, compound 3's estimate is 11.8 percentage points above it; the range from low to high includes it.
By their numbers in this assay, from the lowest: compounds 3, 2 and 1 (each within the scatter of the next, the first and the last beyond it).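

In this assay, among these compounds, the group on this carbonyl carbon now shifts the read-out beyond the scatter for the first time: tert-butyl in place of butyl gives a number 15.1 percentage points lower from compound 1 to compound 3 (beyond the scatter) and so the position is not silent. Tert-butyl in place of hexyl gives a number 7.4 percentage points lower from compound 2 to compound 3 (within the scatter) and so separates nothing, which means the effect appears against the butyl ester only, and the three compounds do not define a clear trend. No measurement shown here explains why the butyl and tert-butyl esters differ.

Still open, from the compounds shown here alone, is whether a ring such as cyclohexyl or phenyl on the same carbonyl carbon would lower the number further. Going by these compounds, a methyl there, the smallest chain of this kind, is also an open case, and with only one concentration the potency of all three compounds remains unknown.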